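This account rests on a few compounds, and the source may have more. Where it says the series, first, only, none or still open, it means among the compounds named here.

Values in a functional assay on UACC-257 cells (Homo sapiens) for cytotoxicity, read by sulforhodamine B assay, with a stated time of 48 h; a higher number here means that more compound is tolerated, a lower number that less compound is tolerated:
compound 1 `ClCc1ccccc1Cn1cnc2c(Cl)nc(Cl)nc21`: 8510 nM
compound 2 `ClCc1cccc(Cn2cnc3c(Cl)nc(Cl)nc32)c1`: 6450 nM
compound 3 `Nc1nc(Cl)c2ncn(Cc3ccccc3CCl)c2n1`: > 100000 nM, a limit of the assay and not a number the limit of > 100000 nM in this assay, at which 1 of the 3 values shown sits.

Compound 1 and compound 2 have the same atoms joined differently; the difference between the two cores is not broken down here, and their two values lie within the usual scatter of each other. From compound 1 to compound 3 the change is amino in place of chloro on an aromatic carbon, and this produced an at least 11-fold higher number from compound 1 to compound 3 (1.07 log units; beyond the scatter).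

Compound 4 `Nc1nc(Cl)c2ncn(Cc3cccc(CCl)c3)c2n1` carries the same change on the core of compound 2: amino in place of chloro on an aromatic carbon. The place is described in identical terms, so this is taken as the same change. The step is expected as a 16-fold higher number from compound 2 to compound 4 (1.19 log units; beyond the scatter), resting on compound 3 and an at least 11-fold higher number from compound 1 to compound 3 (1.07 log units; beyond the scatter). Compound 4 is estimated at 100000 nM, between 40000 nM and 300000 nM, with a limit rather than a number the likely outcome.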

Compound 4, concentration lethal to 50% of the cells: 49000 nM
Estimate against measurement, compound 4: 2.0-fold (0.31 log units) above, and the stated range covers the measured number.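

In this assay, amino in place of chloro on an aromatic carbon also raises the number on the core of compound 2, with a 7.6-fold higher number from compound 2 to compound 4 (0.88 log units; beyond the scatter). The direction of the change therefore holds on both cores shown, and neither pair goes against it. Compound 3 stands at a limit of the assay and not at a number, so whether the size of the step carries over from one core to the other cannot be settled: the same change on two cores in this assay, an at least 11-fold higher number (1.07 log units; beyond the scatter) from compound 1 to compound 3 and a 7.6-fold higher number (0.88 log units; beyond the scatter) from compound 2 to compound 4; the limit leaves it open whether they differ

The compounds shown leave open whether a methoxy group or a dimethylamino group at the same place would give a similar step. Also open, going by these compounds, is what replacing the remaining chloro group with an amino group would do on either core.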